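The source may report more compounds than this note shows. Statements on the series, on what has been measured and on what is new or still open speak of the compounds shown alone.

Compound 1, with the structure `COc1cc(C)cc(-c2c(-c3ccnc(-c4ccc(C(C)=O)cc4)c3)cnn2CC#N)c1`, is one of two compounds for which a measurement exists here. In a functional assay on SN12C cells (Homo sapiens) for cytotoxicity, read by sulforhodamine B assay, with a stated time of 48 h, tested at 0.01 uM (on this read-out lower numbers stand for a stronger effect and higher numbers for a weaker effect at the one concentration tested), compound 1 gives 93%. The other measured compound, compound 2, with the structure `COc1cc(C)cc(-c2nn(CC#N)cc2-c2ccc(-c3cccc(C(C)=O)c3)nc2)c1`, gives in this assay a reading of 88%. On these two numbers compound 1 stands highest, but the gap to compound 2 lies within the usual scatter of such measurements, so the two cannot be told apart.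

The compound now in question is compound 3, with the structure `COc1cc(C)cc(-c2c(-c3ccnc(-c4ccc(N(C)C)cc4)c3)cnn2CC#N)c1`. It differs from compound 1 in one place: dimethylamino in place of acetyl on an aromatic carbon. Going by the values given here, no pair of measured compounds with a single change of this kind exists here, so there is no measured step to lean on. Both measured numbers sit high and close together, so a change that stays within the scatter is expected, with no clear direction. The step from compound 1 to compound 3 in this assay is estimated at a number 2 percentage points lower from compound 1 to compound 3 (within the scatter). For compound 3 itself the expected reading in this assay is 91%, with a range from 78% to 102%.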

Compound 3, a percentage reported as activity, at one concentration (the size of the read-out at that concentration, not a potency): 75%
The estimate for compound 3 lay 16 percentage points above the measured number, outside the stated range (below it).
By their numbers in this assay, from the lowest: compound 3; then compounds 2 and 1 (each within the scatter of the next).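

In this assay, replacing 4-acetylphenyl with 4-(dimethylamino)phenyl gives a number 18 percentage points lower from compound 1 to compound 3 (beyond the scatter), the first change shown here that stands clear of the scatter, so the group at this aromatic carbon does matter to the read-out, and dimethylamino goes with the stronger effect at the one concentration tested. Acetyl and dimethylamino have the same count of 3 heavy atoms, neither has a ring or a net charge, and each counts as 1 hydrogen-bond acceptor, so these counts alone do not separate them; they differ in that a carbonyl, with its oxygen and its double bond, gives way to a nitrogen carrying two carbons. Nothing measured here says why this exchange changes the reading.

Going by these compounds, it remains open whether the effect belongs to dimethylamino in particular or would also appear with a plain amino group, a morpholine ring or a carboxylic acid at the same place. It is equally open whether the same exchange would give a similar step on the core of compound 2, and a single reading at one concentration does not establish a potency for any of these compounds.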